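Moving the Hydroxyl Once More Around the Ring

This account rests on a few compounds, and the source may have more. Where it says the series, first, only, none or still open, it means among the compounds named here.

Among the measured compounds shown here, compound 2 `Oc1ccc(-c2cc(-c3ccco3)cc(-c3cccc(O)c3)n2)cc1` stands highest of the two numbers measured so far: in an assay on isolated protein for inhibition of DNA topoisomerase 1 (Homo sapiens), with a stated time of 30 min, tested at 100 uM (a higher number here means a stronger effect of the compound at the concentration tested, a lower number a weaker effect), compound 2 gives 100%. Its nearest neighbour, compound 1 `Oc1ccc(-c2cc(-c3ccco3)cc(-c3ccccc3O)n2)cc1`, gives 83% in this assay, and the step of a number 17 percentage points higher from compound 1 to compound 2 (beyond the scatter) accompanied 3-hydroxyphenyl in place of 2-hydroxyphenyl on an aromatic carbon. Compound 3 `Oc1ccc(-c2cc(-c3ccco3)cc(-c3ccc(O)cc3)n2)cc1` differs from compound 2 by 4-hydroxyphenyl in place of 3-hydroxyphenyl on an aromatic carbon. For the measured compounds named here, no measured step covers this particular change, and the one available was modest, so the step of a number 10 percentage points lower from compound 2 to compound 3 (within the scatter) is expected to be small or within the scatter. Compound 3 is estimated at 90%, between 75% and 100%.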

Compound 3, a percentage reported as inhibition, at one concentration (the size of the read-out at that concentration, not a potency): 100%
Beside the measured number, compound 3's estimate is 10 percentage points below it; the measured number falls inside the stated range.
By their numbers in this assay, from the lowest: compound 1; then compounds 2 and 3 (each within the scatter of the next).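

In this assay, moving the hydroxyl from the 3-hydroxyphenyl to the 4-hydroxyphenyl group gives no change at the digits printed from compound 2 to compound 3 (within the scatter), while the comparison with the 2-hydroxyphenyl group gives a number 17 percentage points higher from compound 1 to compound 3 (beyond the scatter). Among these three compounds, only the 2-hydroxyphenyl group in compound 1 therefore stands apart. Nothing available explains this difference.

Compound 2 and compound 3 share one reading at a single concentration, which leaves open whether their effects would differ at any other concentration. Also open, on these data alone, is how this position would respond if an aminophenyl or methoxyphenyl group replaced the hydroxyphenyl group.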